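Aryl substituent change on the compound 2 scaffold

The source may hold more compounds than are shown below. What is called first, only, known or untested is meant among the compounds shown, and "the series" means these compounds.

Measured compounds, read in a functional assay on HOS-TE85 cells (Homo sapiens) for inhibition, read by CCK-8 assay, with a stated time of 72 h; a lower number here means a stronger inhibitor, a higher number a weaker inhibitor:
compound 1, `COc1ccc(F)cc1N1C(=O)CSC1c1cccc(C(=O)NCCCCn2cccn2)c1`, gives 97.3 nM.
compound 2, `CCN(CC)c1ccc(N2C(=O)CSC2c2cccc(C(=O)NCCCCc3ccccc3)c2)cc1`, gives > 1000 nM, a limit of the assay.
compound 3, `Cc1ccnc(N2C(=O)CSC2c2cccc(C(=O)NCCCCn3cccn3)c2)c1`, gives 19.6 nM.

Within the data shown here, the one single-point step recorded is a 5.0-fold lower number from compound 1 to compound 3 (0.70 log units; beyond the scatter). For compound 2 the value is a limit and not a number, as noted under (the limit of > 1000 nM in this assay, at which 1 of the 3 values shown sits); compound 2 thus stands at the weak end of what is shown.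

Compound 4, `O=C(NCCCCc1ccccc1)c1cccc(C2SCC(=O)N2c2ccc(C3CC3)cc2)c1`, differs from compound 2 by cyclopropyl in place of diethylamino on an aromatic carbon. No measured step touches this place, since the step of a 5.0-fold lower number from compound 1 to compound 3 (0.70 log units; beyond the scatter) concerns another position; no direction can be drawn from the shown steps, and the expected step is a step that the limit leaves unreadable from compound 2 to compound 4. Compound 4 is expected at 1500 nM, estimated between 300 nM and 8000 nM.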

Compound 4, half-maximal inhibitory concentration: 217 nM
For compound 4 the middle estimate is 6.9-fold (0.84 log units) above the measured one; the measured number lies below the stated range.
By their numbers in this assay, from the lowest: compound 3; then compound 1; then compound 4. At a limit, above all of these: compound 2.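

In this assay, cyclopropyl in place of diethylamino on the aromatic carbon para to a large group gives an at least 4.6-fold lower number from compound 2 to compound 4 (0.66 log units; beyond the scatter). Among these compounds, this is the first readable change at this place, and it shows that this place alone can move the number beyond the scatter, with the rest of compound 2 unchanged. The size of the step is only a lower bound, as compound 2 stands at a limit: the limit of > 1000 nM in this assay, at which 1 of the 4 values shown sits.

On these data alone, it remains open whether dimethylamino or a carboxylic acid at this place would read closer to compound 4 or to compound 2. Also open, as far as these compounds go, is whether the same change holds with the amide side chain of compound 3.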